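The compounds below may be only part of what the source reports. "The series", "measured", "known", "first", "only" and "open" are said of these compounds alone.

Compound 3 `CCCCC(Sc1ccc(OCCCOc2ccc3ncccc3c2)cc1)C(=O)O` stands in an assay for inhibition of Polyunsaturated fatty acid 5-lipoxygenase (Homo sapiens), read by HPLC, with a stated time of 10 min (a higher number here means a weaker inhibitor, a lower number a stronger inhibitor), only as a limit: in this assay compound 3 gives > 10000 nM, a limit of the assay and not a number. Compound 1 `CCCCC(Sc1ccc(OCCCOc2cccc(C)c2)cc1)C(=O)O` gives > 10000 nM in this assay, likewise a limit. Compound 2 `CCCCC(Sc1ccc(OCCCOc2ccc(Cl)cc2OC)cc1)C(=O)O` gives > 10000 nM in this assay, again a limit. The steps a step that the two limits leave unreadable from compound 1 to compound 2, a step that the two limits leave unreadable from compound 1 to compound 3 and a step that the two limits leave unreadable from compound 2 to compound 3 are therefore unreadable because every value sits at the limit of > 10000 nM in this assay, at which 3 of the 3 values shown sit. Compound 4 `CCCCC(Sc1ccc(OCCCOc2cccc(C(C)C)c2)cc1)C(=O)O` differs from compound 3 by 3-isopropylphenyl in place of quinolin-6-yl on an oxygen on a saturated carbon. Going by the values given here, no measured step gives the size of such a change. Compound 4 is expected to remain at the limit, estimated at 15000 nM with a range of 5000 nM to 50000 nM. The expected step that the limit leaves unreadable from compound 3 to compound 4 is thus not distinguishable from none.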

Compound 4, half-maximal inhibitory concentration: 6000 nM
Compound 4: middle estimate off by 2.5-fold (0.40 log units), on the high side; low and high end bracket the measured number.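

In this assay, going by these compounds alone, the 3-isopropylphenyl of compound 4 is the first group on this oxygen on a saturated carbon to give a number and not a limit. The readings are an at least 1.6-fold lower number from compound 3 to compound 4 (0.22 log units; that floor lies within the scatter), an at least 1.6-fold lower number from compound 2 to compound 4 (0.22 log units; that floor lies within the scatter) and an at least 1.6-fold lower number from compound 1 to compound 4 (0.22 log units; that floor lies within the scatter); the last change is isopropyl in place of methyl on an aromatic carbon. Each is only a floor, because the other compound in each pair stands at a limit: the limit of > 10000 nM in this assay, at which 3 of the 4 values shown sit.

From the compounds shown here alone, the true size of these steps stays open. So does the effect of a tert-butyl or an amine on that aromatic carbon.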